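Cyclopropyl for Cyclohexyl on the Amide Nitrogen

The source may report more compounds than this note shows. Statements on the series, on what has been measured and on what is new or still open speak of the compounds shown alone.

Compound 1 `CC(C)=CCC/C(C)=C/CC/C(C)=C/CSC[C@H](NC(=O)CCCCCN1CCCC1)C(=O)NC1CCCCC1` carries a cyclohexyl group on its amide nitrogen. In a functional assay on BXPC-3 cells (Homo sapiens) for cytotoxicity, read by fluorescence, with a stated time of 48 h (on this read-out lower numbers stand for an effect already at smaller amounts and higher numbers for an effect only at larger amounts of compound), compound 1 gives 12700 nM. For the measured compounds named here, that is the only number reported in this assay so far; the one other result is a limit. Compound 2 `CC(C)=CCC/C(C)=C/CC/C(C)=C/CSC[C@H](NC(=O)CCCCCN1CCN(C)CC1)C(=O)NC1CCCC1` stands in this assay at > 20000 nM, which is a limit of the assay and not a number, as described by the limit of > 20000 nM in this assay, at which 1 of the 2 values shown sits. Compound 3 `CC(C)=CCC/C(C)=C/CC/C(C)=C/CSC[C@H](NC(=O)CCCCCN1CCCC1)C(=O)NC1CC1` differs from compound 1 in one place: cyclopropyl in place of cyclohexyl on an amide-type nitrogen. Going by the values given here, no step between two measured compounds isolates this change, so its size can only be anticipated, not read from the data. The step of a 1.6-fold higher number from compound 1 to compound 3 (0.20 log units; within the scatter) is expected to be modest and toward an effect only at larger amounts, perhaps no further than the usual scatter. Compound 3 is therefore expected to give about 20000 nM, between 8000 nM and 45000 nM, with a real chance that only a limit is returned.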

Compound 3, half-maximal effective concentration: > 20000 nM
Compound 3 was reported as a limit; the forecaster's own chance of this, stated with the estimate: 45%; the middle value sits exactly at the limit.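

In this assay compound 3 stands at > 20000 nM, which is a limit of the assay and not a number. Cyclopropyl in place of cyclohexyl on an amide-type nitrogen gives an at least 1.5-fold higher number from compound 1 to compound 3 (0.19 log units; that floor lies within the scatter), the first step that can be read at this position, but it fixes only a floor and does not say how large the change really is. The same limit now recurs among the compounds shown: the limit of > 20000 nM in this assay, at which 2 of the 3 values shown sit.

The compounds shown leave open whether a phenyl, benzyl or cycloheptyl group on this amide-type nitrogen would return a number or a limit in this assay. On these data alone, it also remains open whether the change from cyclohexyl to cyclopropyl would read the same with a dimethylamino group at the end of the chain.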